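The compounds below may be only part of what the source reports. "The series", "measured", "known", "first", "only" and "open" are said of these compounds alone.

Measured compounds:
- compound 1 `O=C1COc2ccc(-c3[nH]c(-c4c[nH]c5ncccc45)nc3-c3ccccc3)cc2N1`: 8.9%
- compound 2 `O=C1COc2ccc(-c3[nH]c(-c4ccccc4)nc3-c3ccccc3)cc2N1`: 7.6%
- compound 3 `O=C1COc2ccc(-c3[nH]c(-c4ccc(C(F)(F)F)cc4)nc3-c3ccccc3)cc2N1`: 0.6%

In a functional assay on MV4-11 cells (Homo sapiens) for cytotoxicity, read by colorimetric assay and MTT assay, with a stated time of 3 days, tested at 20 uM (a higher number here means a weaker effect of the compound at the concentration tested, a lower number a stronger effect), compound 3 has the lowest of the three numbers, yet the steps of a number 8.3 percentage points lower from compound 1 to compound 3 (within the scatter) and a number 7 percentage points lower from compound 2 to compound 3 (within the scatter) both stay within the scatter, so the three compounds cannot be told apart. Compound 4 `O=C1COc2ccc(-c3[nH]c(-c4ccc(Cl)cc4Cl)nc3-c3ccccc3)cc2N1` differs from compound 3 in one place: 2,4-dichlorophenyl in place of 4-(trifluoromethyl)phenyl on an aromatic carbon. Among the compounds with values here, two steps bear on this change. Swapping the aryl group gave a number 1.3 percentage points lower from compound 1 to compound 2 (within the scatter), and adding trifluoromethyl gave a number 7 percentage points lower from compound 2 to compound 3 (within the scatter), each within the scatter. A further change of the same aryl group is therefore expected to give no step beyond the scatter, a number 3.4 percentage points higher from compound 3 to compound 4 (within the scatter). Compound 4 is estimated at 4%, with a range from 0% to 15%.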

Compound 4, a percentage reported as activity, at one concentration (the size of the read-out at that concentration, not a potency): 41.1%
Beside the measured number, compound 4's estimate is 37.1 percentage points below it; the measured number lies above the stated range.
By their numbers in this assay, from the lowest: compounds 3, 2 and 1 (each within the scatter of the next); then compound 4.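

In this assay this aryl position had so far shown no step beyond the scatter, but 2,4-dichlorophenyl gives large steps toward a weaker effect: a number 40.5 percentage points higher from compound 3 to compound 4 (beyond the scatter) and a number 33.5 percentage points higher from compound 2 to compound 4 (beyond the scatter) and also a number 32.2 percentage points higher from compound 1 to compound 4 (beyond the scatter). The position is therefore not indifferent to its aryl group, although the groups of compound 1, compound 2 and compound 3 could not be told apart. Nothing at hand explains this change. As far as these compounds go, whether a single chlorine would give the same result stays open, as does the effect of an amine or a carboxylic acid on this aryl ring.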